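The compounds below may be only part of what the source reports. "The series", "measured", "known", "first", "only" and "open" are said of these compounds alone.

Of the compounds shown here, three sharing one core have been tested in a functional assay on A549 cells (Homo sapiens) for inhibition, read by sulforhodamine B assay, with a stated time of 48 h; on this read-out lower numbers stand for stronger inhibition of growth and higher numbers for weaker inhibition of growth. Compound 1 `COc1ccc2c(c1)NC(=O)CN2c1nc(COC(C)=O)nc2ccccc12` gives 5.52 nM. Compound 2 `COc1ccc2c(c1)NC(=O)CN2c1nc(NC2CC2)nc2ccccc12` gives 1.12 nM, and compound 3 `COc1ccc2c(c1)NC(=O)CN2c1nc(N2CCCC2)nc2ccccc12` gives 45 nM. Among these three numbers compound 1 stands second highest; the nearest number is reached by a 4.9-fold lower number from compound 1 to compound 2 (0.69 log units; beyond the scatter) and the furthest by an 8.2-fold higher number from compound 1 to compound 3 (0.91 log units; beyond the scatter). Compound 4 `COc1ccc2c(c1)NC(=O)CN2c1nc(Nc2ccc(C#N)cc2)nc2ccccc12` has not yet been measured. It differs from compound 1 in one place: (4-cyanophenyl)amino in place of acetoxymethyl on an aromatic carbon. Both measured steps that start from compound 1 change this same position, so both bear on the new one. The step of a 4.9-fold lower number from compound 1 to compound 2 (0.69 log units; beyond the scatter) brought in a group carrying one hydrogen-bond donor, as the (4-cyanophenyl)amino group does, and it lowered the number; the step of an 8.2-fold higher number from compound 1 to compound 3 (0.91 log units; beyond the scatter) brought in a group with no donor and raised it. The large gap a 40-fold higher number from compound 2 to compound 3 (1.60 log units; beyond the scatter) points the same way. Among the measured compounds shown here, no measured compound carries an aromatic ring at this position, so the effect of the larger entering group is untested, and the range must stay wide. Compound 4 is expected to show a 1.8-fold lower number from compound 1 to compound 4 (0.26 log units; within the scatter), a modest lowering. Compound 4 is estimated at 3 nM, within a range from 0.7 nM to 13 nM.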

Compound 4, concentration for 50% growth inhibition: 6.17 nM
Estimate against measurement, compound 4: 2.1-fold (0.31 log units) below; the measured number falls inside the stated range.
By their numbers in this assay, from the lowest: compound 2; then compounds 1 and 4 (each within the scatter of the next); then compound 3.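

In this assay, among the compounds shown here, an aromatic ring stands at this position for the first time, and the step of a 1.1-fold higher number from compound 1 to compound 4 (0.05 log units; within the scatter) lies within the scatter, so the two compounds cannot be told apart. A hydrogen-bond donor in the entering group therefore does not settle the number alone: the amino nitrogen stays in place, yet the step of a 5.5-fold higher number from compound 2 to compound 4 (0.74 log units; beyond the scatter) lies beyond the scatter, so the group carried on that nitrogen also counts. The step of a 7.3-fold lower number from compound 3 to compound 4 (0.86 log units; beyond the scatter) still fits the earlier picture of groups with a donor giving lower numbers than pyrrolidin-1-yl, but compound 1, which has no donor in this group, goes against that picture when set beside compound 4.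

From the compounds shown here alone, a plain phenylamino group would separate the ring from the nitrile, and a methylamino group would show how a smaller group on the same nitrogen compares with cyclopropylamino, so the roles of ring, nitrile and size all stay open. Nothing measured here explains why any of these steps has the size it has.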